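A few compounds are considered here, and "the series" means these few. Any claim that something is new, unique, unknown or untested is made for them only; others in the source may bear on it.

Measured so far in a functional assay on NCI-H460 cells (Homo sapiens) for cytotoxicity, read by MTT assay, with a stated time of 72 h (a higher number here means a weaker inhibitor, a lower number a stronger inhibitor), for this series:
- compound 1 `CCCCNC1=CC(=O)C=C(C(C)(C)C)C1=O` gives 14000 nM
- compound 2 `CCCCCCCCNC1=CC(=O)C=C(C(C)(C)C)C1=O` gives 20000 nM

Among the compounds with values here, compound 2 stands within the scatter of compound 1, the only other measured compound in this assay so far, and the two values show no order.

Next comes compound 3 `CC(C)(C)C1=CC(=O)C=C(NCc2ccccc2)C1=O` with the change phenyl in place of heptyl on a saturated chain carbon bound to an amine nitrogen in view, that is, phenyl in place of heptyl on a saturated chain carbon bound to an amine nitrogen. Within the data shown here, only one measured step bears on this, and it is also a change in the chain on the amine: the data show a 1.4-fold higher number from compound 1 to compound 2 (0.15 log units; within the scatter) for butyl in place of hydrogen on a saturated chain carbon. Among the measured compounds shown here, no measured compound carries phenyl at this place, so the expectation is an extrapolation from that single step. No step beyond the scatter is expected in this assay in either direction. The expected step is a 1.4-fold lower number from compound 2 to compound 3 (0.15 log units; within the scatter) on this estimate. The estimated value for compound 3 is 14000 nM (5000 nM to 35000 nM).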

Compound 3, half-maximal inhibitory concentration: 14000 nM
For compound 3 middle estimate and measured number coincide at the digits printed; low and high end bracket the measured number.
By their numbers in this assay, from the lowest: compounds 1, 3 and 2 (each within the scatter of the next).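

In this assay, phenyl in place of heptyl on a saturated chain carbon bound to an amine nitrogen gives a 1.4-fold lower number from compound 2 to compound 3 (0.15 log units; within the scatter) and phenyl in place of propyl at the same place gives no change at the digits printed from compound 1 to compound 3 (within the scatter) so neither step leaves the scatter. Until now this place had held only open chains, and it now also carries a six-membered aromatic ring of carbon only, with all three compounds within the scatter of one another, so that in this assay chain and ring cannot be told apart by their numbers at this place. Nothing measured on these compounds accounts for how close the three values lie.

The compounds shown contain no group at this place that gives a step beyond the scatter, so no order among substituents on the amine can yet be set out. From the compounds shown here alone, whether a carboxylic acid or a dimethylamino group at the end of the chain, or a methoxy group on the phenyl ring, would move the number beyond the scatter remains open.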